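From a Cyclopropyl Amide to a Furan Amide

A few compounds are considered here, and "the series" means these few. Any claim that something is new, unique, unknown or untested is made for them only; others in the source may bear on it.

Compound 1, `CCCC(=O)Nc1c(C(O)(C(F)(F)F)C(F)(F)F)ccc2ccccc12`, gives 708 nM in a functional assay (Sus scrofa) with sulfonylurea receptors; K-ATP channels (Homo sapiens) as the target; a lower number here means that less compound is needed, a higher number that more compound is needed for the effect.
Compound 2, `O=C(Nc1c(C(O)(C(F)(F)F)C(F)(F)F)ccc2ccccc12)C1CC1`, gives 126 nM in this assay.
Compound 3, `O=C(Nc1c(C(O)(C(F)(F)F)C(F)(F)F)ccc2ccccc12)c1ccc(Cl)cc1`, gives 389 nM in this assay.

All three share one core and differ only in the group on a carbonyl carbon. Compound 2 stands lowest of the three numbers: the step of a 3.1-fold higher number from compound 2 to compound 3 (0.49 log units; beyond the scatter) lies beyond the scatter, and so does the step of a 5.6-fold lower number from compound 1 to compound 2 (0.75 log units; beyond the scatter), while a 1.8-fold lower number from compound 1 to compound 3 (0.26 log units; within the scatter) stays within it.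

Compound 4, `O=C(Nc1c(C(O)(C(F)(F)F)C(F)(F)F)ccc2ccccc12)c1ccco1`, carries the change (furan-2-yl in place of cyclopropyl on a carbonyl carbon). Going by the values given here, no measured step covers a furan-2-yl group, so the steps that bear on it are the two that exchange cyclopropyl for another group, a 5.6-fold lower number from compound 1 to compound 2 (0.75 log units; beyond the scatter) read backwards and a 3.1-fold higher number from compound 2 to compound 3 (0.49 log units; beyond the scatter); both leave cyclopropyl with a higher number. Among the compounds with values here, a modest rise is therefore expected for compound 4, a 2.0-fold higher number from compound 2 to compound 4 (0.30 log units; within the scatter), though a furan-2-yl group has no measured precedent and the direction is uncertain. The estimate for compound 4 in this assay is 250 nM, with a range from 100 nM to 700 nM.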

Compound 4, half-maximal effective concentration: 182 nM
The estimate for compound 4 lay 1.4-fold (0.14 log units) above the measured number; measured number inside the range.
By their numbers in this assay, from the lowest: compounds 2 and 4 (each within the scatter of the next); then compounds 3 and 1 (each within the scatter of the next).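

In this assay, furan-2-yl in place of cyclopropyl gives a 1.4-fold higher number from compound 2 to compound 4 (0.16 log units; within the scatter) so the two groups cannot be told apart here, although furan-2-yl adds heavy atoms, an aromatic ring and a hydrogen-bond acceptor. Going by these compounds alone, until now the only aromatic group at this carbonyl carbon was 4-chlorophenyl, and the new result, a 2.1-fold lower number from compound 3 to compound 4 (0.33 log units; beyond the scatter) shows that an aromatic ring here need not bring the higher number seen with compound 3. The propyl chain also gives way to furan-2-yl with a 3.9-fold lower number from compound 1 to compound 4 (0.59 log units; beyond the scatter) so compound 2 and compound 4 both separate from compound 1, while compound 3, the exception, stays within the scatter of it.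

The compounds shown leave open whether the ring oxygen of furan-2-yl matters, which a thiophen-2-yl group would test, and whether the chlorine sets compound 3 apart, which a plain phenyl group would test. No available measurement explains the differences among these groups.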